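Swapping a Methoxy for Fluoro on the Shared Core

The source may hold more compounds than are shown below. What is called first, only, known or untested is meant among the compounds shown, and "the series" means these compounds.

Compound 2 `COc1ccc(CCCOC(=O)N(c2ccccc2)C2CN3CCC2CC3)cc1OC` holds the higher of the two numbers measured in an assay on CHO cells for displacement of a labelled ligand from muscarinic acetylcholine receptor M5 (Homo sapiens), read by scintillation counting, with a stated time of 2 h (on this read-out lower numbers stand for stronger inhibition and higher numbers for weaker inhibition), where compound 2 gives 1610 nM. Its nearest neighbour, compound 1 `COc1ccc(CCCOC(=O)N(c2ccccc2)C2CN3CCC2CC3)cc1`, gives 640 nM in this assay. Among the measured compounds shown here, the step of a 2.5-fold higher number from compound 1 to compound 2 (0.40 log units; beyond the scatter), methoxy in place of hydrogen on an aromatic carbon, is the only measured step that bears on compound 3 `COc1ccc(CCCOC(=O)N(c2ccccc2)C2CN3CCC2CC3)cc1F`, which differs from compound 2 by fluoro in place of methoxy on an aromatic carbon. Because that step a 2.5-fold higher number from compound 1 to compound 2 (0.40 log units; beyond the scatter) was modest and fluoro is counted as one heavy atom, compound 3 is expected to sit at 950 nM, within 400 nM to 2200 nM. This corresponds to an estimated step of a 1.7-fold lower number from compound 2 to compound 3 (0.23 log units; within the scatter).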

Compound 3, inhibition constant: 260 nM
Estimate against measurement, compound 3: 3.7-fold (0.56 log units) above, and the stated range ends above it.
By their numbers in this assay, from the lowest: compound 3; then compound 1; then compound 2.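

In this assay, this position, ortho to a methoxy group, turns out to move in both directions: fluoro in place of hydrogen gives a 2.5-fold lower number from compound 1 to compound 3 (0.39 log units; beyond the scatter), the opposite direction to the step seen with methoxy. The exchange of methoxy for fluoro gives a 6.2-fold lower number from compound 2 to compound 3 (0.79 log units; beyond the scatter), a larger step than either change from hydrogen at this position. Nothing available explains this difference between the two groups.

From the compounds shown here alone, whether chloro, trifluoromethyl or hydroxyl at this position would follow fluoro or methoxy remains open. So does how fluoro would read on a ring without the other methoxy group.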